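Removing the Bromine from a Dipyridyl Hydrazone Antiproliferative

The compounds below may be only part of what the source reports. "The series", "measured", "known", "first", "only" and "open" are said of these compounds alone.

Compound 1 `O=C(NN=C(c1ccccn1)c1ccccn1)c1cccc(Br)c1` gives the lowest of the two numbers recorded in an ADME assay on cells (Homo sapiens) for antiproliferative activity, read by MTT assay; on this read-out lower numbers stand for stronger inhibition and higher numbers for weaker inhibition: compound 1 gives 240 nM. For the measured compounds named here, the only other measured compound, compound 2 `C/C(=N\NC(=O)c1ccc(O)cc1)c1cnccn1`, sits far apart; in this assay compound 2 gives 16800 nM, a gap beyond the usual scatter. Compound 3 `O=C(NN=C(c1ccccn1)c1ccccn1)c1ccccc1` has not yet been measured. It differs from compound 1 in one place: hydrogen in place of bromo on an aromatic carbon. Going by the values given here, no pair of measured compounds shows this change, so no step size is known for it. Since compound 1 gives 240 nM with the bromo present, removing that one heavy atom is expected to shift this assay only modestly toward a higher number, a step of a 1.8-fold higher number from compound 1 to compound 3 (0.24 log units; within the scatter). Compound 3 is therefore estimated at 420 nM, within a range from 130 nM to 1400 nM.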

Compound 3, half-maximal inhibitory concentration: 3040 nM
Compound 3: the middle estimate sits 7.2-fold (0.86 log units) below what was measured, and the stated range ends below it.
By their numbers in this assay, from the lowest: compound 1; then compound 3; then compound 2.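

In this assay, the change from 3-bromophenyl to phenyl gives a 13-fold higher number from compound 1 to compound 3 (1.10 log units; beyond the scatter), so this single heavy atom on the aromatic carbon carries a large part of the activity of compound 1. For the compounds shown here, no measured pair had isolated this position before, and the step now shows that the position is sensitive to this change, even though no ring, charge, or hydrogen-bond donor or acceptor enters or leaves. Nothing available explains why removing the bromo has so large an effect.

The compounds shown leave open whether the bromine itself is needed or whether chloro, methyl or trifluoromethyl on the same carbon would do as well. They also leave open how an amine or a methoxy group there would compare with the bromo of compound 1.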